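Inverting the Carbinol Centre on the Oxetane-Bearing Analogue

The source may hold more compounds than are shown below. What is called first, only, known or untested is meant among the compounds shown, and "the series" means these compounds.

Compound 1: `COc1cc(C)[nH]c(=O)c1CN1CCc2c(Cl)cc(-c3c(C)noc3C)c(Cl)c2C1=O` gives 0.15 nM in an assay for inhibition of histone-lysine N-methyltransferase EZH2 variant Y641N (Homo sapiens), read by scintillation counting, with a stated time of 60 min, in the presence of a further agent that is not named here; a higher number here means a weaker inhibitor, a lower number a stronger inhibitor. Compound 2: `COc1cc(C)[nH]c(=O)c1CN1CCc2c(Cl)cc([C@H](O)C3COC3)c(Cl)c2C1=O` gives 1.5 nM in this assay.

Compound 2 stands at the higher of the two numbers, its nearest neighbour being compound 1 because of a 10-fold higher number from compound 1 to compound 2 (1.00 log units; beyond the scatter). Compound 3, `COc1cc(C)[nH]c(=O)c1CN1CCc2c(Cl)cc([C@@H](O)C3COC3)c(Cl)c2C1=O`, differs from compound 2 only in this: the two compounds have the same atoms and bonds and differ only in configuration as drawn: 1 of 1 stereo elements differ; a stereocentre at a saturated chain carbon is drawn R in compound 2 and S in compound 3. For the measured compounds named here, no measured step bears on a change of configuration alone; the single measured step concerns a group exchange and says nothing about this. Compound 3 is therefore expected to show a 1.7-fold higher number from compound 2 to compound 3 (0.22 log units; within the scatter), with wide uncertainty, giving an estimate of 2.5 nM within 0.5 nM to 20 nM.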

Compound 3, inhibition constant in the histone-lysine N-methyltransferase EZH2 assay: 1500 nM
Estimate against measurement, compound 3: 600-fold (2.78 log units) below; the measured number lies above the stated range.
By their numbers in the histone-lysine N-methyltransferase EZH2 assay, from the lowest: compound 1; then compound 2; then compound 3.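

In the histone-lysine N-methyltransferase EZH2 assay compound 2 gives 1.5 nM and compound 3 gives 1500 nM, so this carbinol centre proves decisive, with a 1000-fold higher number from compound 2 to compound 3 (3.00 log units; beyond the scatter), and that gap belongs to the stereocentre alone: the fact that compounds 2 and 3 differ only in the configuration as drawn

Measured against the five-membered aromatic ring of compound 1, the four-membered ring group in its S form gives a 10000-fold higher number from compound 1 to compound 3 (4.00 log units; beyond the scatter), so the cost of that exchange depends on how the carbinol is drawn. In a physicochemical assay for lipophilicity, at pH 7.4 (a higher number here means a more lipophilic compound, a lower number a more polar compound), compound 2 gives 1.4 and compound 3 gives 1.3; the inversion gives a number 0.10 log units lower from compound 2 to compound 3 (within the scatter), so that read-out does not separate the pair.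

The compounds shown leave open whether inversion costs as much with an amine in place of the hydroxyl group, or with a longer chain in place of the four-membered ring.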